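Swapping Chloro for Fluoro on the Benzoyl Ring

A few compounds are considered here, and "the series" means these few. Any claim that something is new, unique, unknown or untested is made for them only; others in the source may bear on it.

Of the compounds shown here, three have been measured in an ADME assay on J774 cells (Mus musculus, strain BALB/c) for cytotoxicity, read by resazurin assay, with a stated time of 72 h; a lower number here means that less compound is tolerated, a higher number that more compound is tolerated.
Compound 1 `CC(/C=N/Nc1ccc([N+](=O)[O-])cc1)=N\NC(=O)c1ccccc1Cl` gives only a limit in this assay, > 100000 nM.
Compound 2 `CC(/C=N/Nc1ccc([N+](=O)[O-])cc1)=N\NC(=O)c1ccc(N)cc1` gives 75000 nM.
Compound 3 `CC(/C=N/Nc1ccc([N+](=O)[O-])cc1)=N\NC(=O)c1ccc(O)cc1` gives 51000 nM.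

Compound 1 therefore stands at the edge of what this assay can report, as shown by the limit of > 100000 nM in this assay, at which 1 of the 3 values shown sits. Compound 4 `CC(/C=N/Nc1ccc([N+](=O)[O-])cc1)=N\NC(=O)c1ccccc1F` differs from compound 1 by fluoro in place of chloro on an aromatic carbon. The measured steps, an at least 1.3-fold lower number from compound 1 to compound 2 (0.12 log units; that floor lies within the scatter) and an at least 1.9-fold lower number from compound 1 to compound 3 (0.29 log units; that floor lies within the scatter), exchange the whole 2-chlorophenyl group rather than the chloro alone, and both start from a limit, so neither bears directly on this change; a 1.5-fold lower number from compound 2 to compound 3 (0.17 log units; within the scatter) lies within the scatter as well. No step beyond the scatter is therefore expected from compound 1 to compound 4, and the expected step is a number no higher from compound 1 to compound 4 (the limit leaves the size open). Compound 4 is estimated at 100000 nM, with a range from 50000 nM to 250000 nM.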

Compound 4, half-maximal cytotoxic concentration: > 100000 nM
Compound 4 gave a limit, no number; the forecaster's own chance of this, stated with the estimate: 60%; the middle value lies on the limit itself.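

In this assay compound 4 also gives only a limit, so at this place, ortho to a large group, reaching the limit is not confined to chloro: the limit of > 100000 nM in this assay, at which 2 of the 4 values shown sit. The step between compound 1 and compound 4 cannot be read. Compound 4 shows an at least 1.9-fold higher number from compound 3 to compound 4 (0.29 log units; that floor lies within the scatter) and an at least 1.3-fold higher number from compound 2 to compound 4 (0.12 log units; that floor lies within the scatter), so neither comparison separates these compounds beyond the scatter.

Where compound 1 and compound 4 lie beyond their limits stays open. So does whether a methyl, methoxy or trifluoromethyl group at this place would give a readable number.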